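A few compounds are considered here, and "the series" means these few. Any claim that something is new, unique, unknown or untested is made for them only; others in the source may bear on it.

Of the compounds shown here, three with a shared core have been measured in an assay on CHO cells for displacement of a labelled ligand from adenosine receptor A3 (Homo sapiens); a higher number here means a weaker inhibitor, a lower number a stronger inhibitor. Compound 1 `Cc1ccc(NC(=O)c2nc(N)nc3ccccc23)cc1` gives 98.3 nM. Compound 2 `O=C(Nc1ccc(Br)cc1)c1nc(=O)[nH]c2ccccc12` gives 27.2 nM. Compound 3 `CC(=O)Nc1nc(C(=O)Nc2ccccc2)c2ccccc2n1` gives 25.3 nM, the lowest of the three numbers. Compound 2 is nearest to compound 3, and the gap between the two lies within the usual scatter of the assay, so they cannot be told apart on these numbers. Compound 1 is furthest from compound 3, and that gap lies beyond the scatter.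

Compound 4 `O=C(Nc1nc(C(=O)Nc2ccccc2)c2ccccc2n1)c1ccccc1` has not yet been measured. It differs from compound 3 in one place: phenyl in place of methyl on a carbonyl carbon, which reads as acetamido to benzamido on the core. Within the data shown here, no pair of measured compounds shows this change, so its effect has to be guessed from the change alone. In this assay compound 4 is expected to give 20 nM, with a plausible range from 6 nM to 70 nM. On these data alone, the step from compound 3 to compound 4 is therefore expected to be a 1.3-fold lower number from compound 3 to compound 4 (0.10 log units; within the scatter), a small move that may well stay within the scatter, and whether the measurement confirms this remains open.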

Compound 4, inhibition constant: 182 nM
Beside the measured number, compound 4's estimate is 9.1-fold (0.96 log units) below it, outside the stated range (above it).
By their numbers in this assay, from the lowest: compounds 3 and 2 (each within the scatter of the next); then compounds 1 and 4 (each within the scatter of the next).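

In this assay, among these compounds, the change from acetamido to benzamido gives a 7.2-fold higher number from compound 3 to compound 4 (0.86 log units; beyond the scatter) and so is the first change in one place that can be read. It shows that this carbonyl carbon does not accept any group equally: with phenyl in place of methyl, compound 4 is the weaker inhibitor, although the step adds only carbon atoms and one aromatic ring, with no hydrogen-bond donor or acceptor and no net charge entering or leaving. No measurement shown here accounts for the weaker binding of compound 4.

With only methyl and phenyl seen at this place, the compounds shown do not tell whether the number already climbs with an ethyl group or a longer chain, or only with a ring such as cyclohexyl. On these data alone, it also remains open whether a phenyl ring carrying a methoxy group or a chlorine atom would behave like the plain phenyl, or whether a small amine on the carbonyl carbon would hold the number near that of compound 3.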